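The source may hold more compounds than are shown below. What is called first, only, known or untested is meant among the compounds shown, and "the series" means these compounds.

Measured compounds in an ADME assay on HepG2 2.2.15 cells (Homo sapiens) for cytotoxicity; on this read-out lower numbers stand for higher toxicity in this test and higher numbers for lower toxicity in this test:
- compound 1, `O=C(Nc1ncc(Cc2ccc(F)cc2)s1)c1ccc(Br)cc1`: compound 1 gives > 50000 nM, which is a limit of the assay and not a number.
- compound 2, `CCN(CC)C(=O)Nc1ncc(C(Oc2ccc3cc(Br)ccc3c2)c2ccc(Cl)cc2)s1`: compound 2 is recorded as "not toxic" (no number reported), without a number.
- compound 3, `CC(=O)O[C@@H]1OC(C(=O)Nc2ncc(C(Oc3ccc4cc(Br)ccc4c3)c3ccc(Cl)cc3)s2)[C@@H](OC(C)=O)[C@@H](OC(C)=O)[C@H]1OC(C)=O`: compound 3 is likewise recorded as "not toxic" (no number reported).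

Compound 2 therefore stands on no single number in this assay; of the other two entries, one is a limit and one is an entry without a number. Within the data shown here, the only anchor on the scale is the limit of > 50000 nM in this assay, at which 1 of the 3 values shown sits, and no step between measured compounds can be computed from these entries.

Compound 4, `O=S(=O)(Nc1ncc(C(Oc2ccc3cc(Br)ccc3c2)c2ccc(Cl)cc2)s1)c1cccc2nsnc12`, differs from compound 2 in one place: a group of 12 heavy atoms (6 carbon, 2 nitrogen, 2 oxygen, 2 sulfur; one five-membered aromatic ring with 3 hetero atoms, one six-membered aromatic ring of carbon only) in place of a group of 7 heavy atoms (5 carbon, 1 nitrogen, 1 oxygen; no ring), on a nitrogen on an aromatic ring.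

Among the measured compounds shown here, since no measured step is available in this assay, no direction or size of change beyond the usual scatter can be stated for the move from compound 2 to compound 4; the expectation is that compound 4 again shows no measurable toxicity within the tested range. On that basis compound 4 is estimated at 50000 nM, with a range from 15000 nM to 150000 nM.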

Compound 4, half-maximal cytotoxic concentration: "not toxic" (no number reported)
The entry for compound 4 holds no number; no gap can be computed for the estimate.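

In this assay compound 2 and compound 4 are both recorded as "not toxic" without a number, so no step can be read between them. Left open is where on the scale, if anywhere, any of these compounds shows measurable toxicity, with only one anchor available: the limit of > 50000 nM in this assay, at which 1 of the 4 values shown sits.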